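The compounds below may be only part of what the source reports. "The series", "measured", "known", "first", "only" and "open" are said of these compounds alone.

Of the compounds shown here, three have been measured in a functional assay on CCRF-CEM cells (Homo sapiens) for cytotoxicity, read by sulforhodamine B assay, with a stated time of 48 h; on this read-out higher numbers stand for weaker inhibition of growth and lower numbers for stronger inhibition of growth. Compound 3 `ClCc1ccc(Cn2cnc3c(Cl)nc(Cl)nc32)cc1` gives 1950 nM, compound 1 `Nc1nc(Cl)c2ncn(Cc3ccc(CCl)cc3)c2n1` gives 2690 nM, and compound 2 `ClCc1cccc(Cn2cnc3c(Cl)nc(Cl)nc32)c1` gives 2690 nM. Compound 1 arises from compound 3 by amino in place of chloro on an aromatic carbon, a change that produced a 1.4-fold higher number from compound 3 to compound 1 (0.14 log units; within the scatter). Compound 2 and compound 3 have the same atoms joined differently; the difference between the two cores is not broken down here. Compound 4 `Nc1nc(Cl)c2ncn(Cc3cccc(CCl)c3)c2n1` has not yet been measured in this assay; it arises from compound 2 by the same change, (amino in place of chloro on an aromatic carbon). Because the measured pair showed a 1.4-fold higher number from compound 3 to compound 1 (0.14 log units; within the scatter), a step of similar size is expected here, namely a 1.3-fold higher number from compound 2 to compound 4 (0.11 log units; within the scatter). Compound 4 is therefore estimated at 3500 nM, with a likely range from 1500 nM to 8000 nM.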

Compound 4, concentration for 50% growth inhibition: 3020 nM
For compound 4 the middle estimate is 1.2-fold (0.06 log units) above the measured one; the measured number falls inside the stated range.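

In this assay, amino in place of chloro on an aromatic carbon gives a 1.1-fold higher number from compound 2 to compound 4 (0.05 log units; within the scatter). As far as these two pairs can tell, the change carries from one core to the other without a visible difference: the same change on two cores in this assay, a 1.4-fold higher number (0.14 log units; within the scatter) from compound 3 to compound 1 and a 1.1-fold higher number (0.05 log units; within the scatter) from compound 2 to compound 4, 1.2-fold (0.09 log units) apart, within the scatter of two such steps. Within the data shown here, this shows only that the change leaves the number within the scatter on both cores; it does not show that the change has any real effect, or that the same would hold on a third core.

The compounds shown leave open whether a methoxy group or a dimethylamino group in that place would move the number beyond the scatter. They also leave open what a longer chain ending in chloro would do in place of the chloromethyl group.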